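The source may report more compounds than this note shows. Statements on the series, on what has been measured and on what is new or still open speak of the compounds shown alone.

Compound 3 `COc1cc(-c2nn(-c3cccc(NC(=O)Nc4ccc(Cl)c(C(F)(F)F)c4)c3)cc2-c2ccncc2)ccc1Cl` stands second highest of the three numbers in a functional assay on SF-295 cells (Homo sapiens) for inhibition, read by sulforhodamine B assay, with a stated time of 48 h; a higher number here means a weaker inhibitor of growth, a lower number a stronger inhibitor of growth; in this assay compound 3 gives 2540 nM. Its nearest neighbour is compound 2 `COc1cc(-c2nn(-c3cccc(NC(=O)Nc4ccc(Cl)c(Cl)c4)c3)cc2-c2ccncc2)ccc1Cl`, which in this assay gives 2530 nM; the step of a 1.0-fold higher number from compound 2 to compound 3 (0.00 log units; within the scatter) is within the scatter. Compound 1 `O=C(Nc1cccc(-n2cc(-c3ccncc3)c(-c3ccc(Cl)c(O)c3)n2)c1)Nc1cccc(C(F)(F)F)c1` in this assay gives 4260 nM, also within the scatter of compound 3.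

Compound 4 `O=C(Nc1cccc(-n2cc(-c3ccncc3)c(-c3ccc(Cl)c(O)c3)n2)c1)Nc1ccc(Cl)c(C(F)(F)F)c1` differs from compound 3 by hydrogen in place of methyl on an oxygen on an aromatic ring. Within the data shown here, no measured step isolates this change. Among the measured compounds shown here, compound 1 carries the hydroxy group but differs from compound 3 in a second place as well, and its value is within the scatter of compound 3; the only measured step, a 1.0-fold higher number from compound 2 to compound 3 (0.00 log units; within the scatter), concerns a different position and is within the scatter. Compound 4 is therefore expected to give in this assay a number near that of compound 3, with a step of a 1.3-fold higher number from compound 3 to compound 4 (0.10 log units; within the scatter) not expected to exceed the scatter. The estimate for compound 4 in this assay is 3200 nM, with a range from 1300 nM to 8000 nM.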

Compound 4, concentration for total growth inhibition: 2060 nM
Compound 4: middle estimate off by 1.6-fold (0.19 log units), on the high side, and the stated range covers the measured number.
By their numbers in this assay, from the lowest: compounds 4, 2, 3 and 1 (each within the scatter of the next, the first and the last beyond it).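

In this assay the change from methoxy to hydroxy on the 4-chloro-3-methoxyphenyl group gives a 1.2-fold lower number from compound 3 to compound 4 (0.09 log units; within the scatter) and so shows no readable difference between these two groups at this oxygen when the rest of the molecule is held fixed. With the hydroxy group kept in place, chloro in place of hydrogen on an aromatic carbon gives a 2.1-fold lower number from compound 1 to compound 4 (0.32 log units; beyond the scatter) and is a modest step, the only one among the compounds shown that lies beyond the scatter. Nothing available here offers an explanation for either step.

The compounds shown place only hydroxy and methoxy at this position, so how an ethoxy group or an amine there would read stays open. Going by these compounds, whether the chloro step would be repeated with methoxy in place of hydroxy also stays open.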